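Removing One Fluorine: From Compound 2 to Compound 4

A few compounds are considered here, and "the series" means these few. Any claim that something is new, unique, unknown or untested is made for them only; others in the source may bear on it.

In an assay on isolated protein for inhibition of ubiquitin carboxyl-terminal hydrolase 7 (Homo sapiens), read by fluorescence, with stated times of 30 min and 3 h (a lower number here means a stronger inhibitor, a higher number a weaker inhibitor), compound 2 `O=C(NCc1cccc(F)c1)c1nc([N+](=O)[O-])c(Sc2c(Cl)cncc2Cl)s1` gives 1350 nM, the lowest of the two numbers available. Compound 3 `CC(=O)c1nc([N+](=O)[O-])c(Sc2ccc(F)cc2F)s1` gives 6120 nM in this assay, a higher number, and that gap lies beyond the scatter. Compound 1 `COc1cccc(Sc2sc(C(C)=O)nc2[N+](=O)[O-])c1` gives only a limit, > 50000 nM, which is noted as the limit of > 50000 nM in this assay, at which 1 of the 3 values shown sits.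

The unmeasured compound 4 `O=C(NCc1ccccc1)c1nc([N+](=O)[O-])c(Sc2c(Cl)cncc2Cl)s1` differs from compound 2 by hydrogen in place of fluoro on an aromatic carbon. Within the data shown here, no pair of measured compounds shows this change, so no measured step guides the expectation; a shift no larger than the scatter, in either direction, is expected. Compound 4 is therefore estimated at 1800 nM, within a range from 700 nM to 5000 nM, which means an expected step of a 1.3-fold higher number from compound 2 to compound 4 (0.12 log units; within the scatter).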

Compound 4, half-maximal inhibitory concentration: 4210 nM
Estimate against measurement, compound 4: 2.3-fold (0.37 log units) below, within the range that was stated.
By their numbers in this assay, from the lowest: compound 2; then compounds 4 and 3 (each within the scatter of the next). At a limit, above all of these: compound 1.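

The earlier compounds shown here offered no pair differing in one place; here, in this assay, hydrogen in place of fluoro on this aromatic carbon gives a 3.1-fold higher number from compound 2 to compound 4 (0.49 log units; beyond the scatter) and takes the 3-fluorobenzyl group to benzyl. So this position responds to the change, and the fluoro goes with the lower number, though only one modest step supports this. Nothing measured here accounts for the step.

Still open, going by these compounds, is how an amine or a carboxylic acid on this same carbon would read. Also open, on these data alone, is whether fluoro on another carbon of this ring would give a similar step.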